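Dimethylcarbamoyl oxazole ketone awaiting its lipase inhibition value

The source may report more compounds than this note shows. Statements on the series, on what has been measured and on what is new or still open speak of the compounds shown alone.

The two measured compounds share a ketone bearing a phenyl-terminated chain on a five-membered aromatic core. Compound 1 `COc1coc(C(=O)CCCCCCc2ccccc2)n1` carries a methoxy group on that core. In an assay on HEK-293T cells for inhibition of diacylglycerol lipase-alpha (Homo sapiens), read by colorimetric assay (on this read-out lower numbers stand for stronger inhibition and higher numbers for weaker inhibition), compound 1 gives only a limit, > 10000 nM. Compound 2 `CS(=O)(=O)c1cnc(C(=O)CCCCCCc2ccccc2)o1` carries a methylsulfonyl group instead. In this assay compound 2 also gives only a limit, > 10000 nM. Within the data shown here, both values therefore rest at the limit of > 10000 nM in this assay, at which 2 of the 2 values shown sit, and no step between measured compounds can be read from them. Compound 3 `CN(C)C(=O)c1cnc(C(=O)CCCCCCc2ccccc2)o1` differs from compound 2 by dimethylcarbamoyl in place of methylsulfonyl on an aromatic carbon. Since both measured compounds sit at the limit, no change beyond the usual scatter is expected from compound 2 to compound 3, and the step that the limit leaves unreadable from compound 2 to compound 3 is the expected outcome. Compound 3 is accordingly estimated at 12000 nM, within a range from 2500 nM to 60000 nM.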

Compound 3, half-maximal inhibitory concentration: > 10000 nM
Compound 3 was reported as a limit; the forecaster's own chance of this, stated with the estimate: 65%; the middle value is on the limit's open side.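

Among these compounds, compound 3, like compound 2, is reported only as a limit in this assay, so no step from compound 2 to compound 3 can be read: the limit of > 10000 nM in this assay, at which 3 of the 3 values shown sit.

The compounds shown leave open how strongly each of them inhibits, and whether any group on the shared core gives a value that is not a limit.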